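The source may hold more compounds than are shown below. What is called first, only, known or untested is meant among the compounds shown, and "the series" means these compounds.

Measured so far:
- compound 1 `COc1cc(Cn2cc(CNC(=O)c3cn(-c4ccccc4)nc3-c3ccccc3)nn2)cc(OC)c1OC`: in a functional assay on HeLa cells (Homo sapiens) for antiproliferative activity, read by sulforhodamine B assay, with a stated time of 48 h (a higher number here means a weaker inhibitor of growth, a lower number a stronger inhibitor of growth), compound 1 gives only a limit, > 100000 nM
- compound 2 `COc1cc(Cn2cc(CNC(=O)c3cn(-c4ccccc4)nc3-c3ccc(F)cc3)nn2)cc(OC)c1OC`: compound 2 gives 2100 nM
- compound 3 `COc1ccc(Cn2cc(CNC(=O)c3cn(-c4ccccc4)nc3-c3ccc(Cl)cc3)nn2)cc1`: compound 3 gives 1400 nM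

Compound 3 has the lowest of the two numbers; its nearest neighbour is compound 2, whose number lies within the scatter of it, and the value of compound 1 is a limit (the limit of > 100000 nM in this assay, at which 1 of the 3 values shown sits). Compound 4 `COc1cc(Cn2cc(CNC(=O)c3cn(-c4ccccc4)nc3-c3ccc(Cl)cc3)nn2)cc(OC)c1OC` differs from compound 3 by 3,4,5-trimethoxyphenyl in place of 4-methoxyphenyl on a saturated chain carbon bound to an aromatic nitrogen. For the measured compounds named here, no measured step covers this change; the only measured step, an at least 47-fold lower number from compound 1 to compound 2 (1.67 log units; beyond the scatter), swaps the halogen instead. Compounds 2 and 3 differ in both places and still sit within the scatter of each other. Compound 4 is therefore expected to stay close to compound 3, with a 1.3-fold higher number from compound 3 to compound 4 (0.11 log units; within the scatter) not beyond the scatter. For compound 4 the estimate is 1800 nM, between 500 nM and 7000 nM.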

Compound 4, concentration for 50% growth inhibition: 100 nM
Compound 4: middle estimate off by 18-fold (1.26 log units), on the high side, outside the stated range (below it).
By their numbers in this assay, from the lowest: compound 4; then compounds 3 and 2 (each within the scatter of the next). At a limit, above all of these: compound 1.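

In this assay, for the compounds shown here, the benzyl position proves sensitive, which the earlier compounds did not show: 3,4,5-trimethoxyphenyl in place of 4-methoxyphenyl gives a 14-fold lower number from compound 3 to compound 4 (1.15 log units; beyond the scatter), and with that group held fixed, chloro in place of fluoro gives a 21-fold lower number from compound 2 to compound 4 (1.32 log units; beyond the scatter). Chloro in place of hydrogen gives an at least 1000-fold lower number from compound 1 to compound 4 (3.00 log units; beyond the scatter), but compound 1 gives only a limit: the limit of > 100000 nM in this assay, at which 1 of the 4 values shown sits. Nothing measured here explains why these changes matter.

From the compounds shown here alone, it remains open whether bromo or methyl in place of chloro would hold the number of compound 4. Whether an amine or a hydroxy group could replace a methoxy group of the 3,4,5-trimethoxyphenyl also remains unsettled.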